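Carbamate ureas: chloro replaces 4-methoxyphenyl on the core

A few compounds are considered here, and "the series" means these few. Any claim that something is new, unique, unknown or untested is made for them only; others in the source may bear on it.

Within the data shown here, the three measured members share a bicyclic core bearing a urea-linked chain. Compound 1 `COc1ccc(-c2ccc3c(c2)oc(=O)n3C(=O)NCCCCc2ccccc2)cc1` carries a 4-methoxyphenyl on that core; in an assay on HEK293 cells for inhibition of acid ceramidase (Homo sapiens), with a stated time of 10 min (a lower number here means a stronger inhibitor, a higher number a weaker inhibitor), compound 1 gives 67 nM. Compound 2 `O=C(NCCCCc1ccccc1)n1c(=O)oc2ccc(-c3ccc(F)cc3)cc21` gives 56 nM and compound 3 `O=C(NCCCCc1ccc2ccccc2c1)n1c(=O)oc2ccccc21`, with an unsubstituted core and a naphthyl-terminated chain, gives 71 nM. Compound 1 sits second highest of the three numbers, but its gaps to compound 3 and to compound 2 are both within the scatter, so the three behave as one group on this read-out.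

Compound 4 `O=C(NCCCCc1ccccc1)n1c(=O)oc2cc(Cl)ccc21` has not been measured. Relative to compound 1 the change is chloro in place of 4-methoxyphenyl on an aromatic carbon. Among the measured compounds shown here, no measured pair isolates this change. Since compound 3, without any substituent at that position, gives 71 nM, the core substituent appears to carry little weight among these three; a small step toward a higher number, within the scatter, is expected a 1.5-fold higher number from compound 1 to compound 4 (0.17 log units; within the scatter). Compound 4 is estimated at 100 nM, within 40 nM to 300 nM.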

Compound 4, half-maximal inhibitory concentration: 33 nM
Beside the measured number, compound 4's estimate is 3.0-fold (0.48 log units) above it; measured number outside the range, below it.
By their numbers in this assay, from the lowest: compounds 4, 2, 1 and 3 (each within the scatter of the next, the first and the last beyond it).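

In this assay, among these compounds, chloro in place of 4-methoxyphenyl on an aromatic carbon gives a 2.0-fold lower number from compound 1 to compound 4 (0.31 log units; beyond the scatter), a modest change, and the only step between compounds differing in one place read so far. At this position of the shared core, the aromatic ring and the hydrogen-bond acceptor of 4-methoxyphenyl are therefore not required for a number at this level, and a group with no ring is accepted.

With the chain of compound 4 held constant, a hydrogen, a bromo, a methyl, an amine or a carboxylic acid at this position would show whether the lower number belongs to chloro itself or simply to the loss of 4-methoxyphenyl. Nothing at hand bears on the reason for this step.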